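Epimer at the peroxide ring carbon in a terpenoid series

The source may hold more compounds than are shown below. What is called first, only, known or untested is meant among the compounds shown, and "the series" means these compounds.

Among the measured compounds shown here, compound 1, `C=C1CCC[C@H]2[C@](C)(CC[C@]3(C)CC[C@H]([C@@H](C)C(=O)O)OO3)[C@@H](C)CC[C@]12C`, gives the only numeric value so far: in a functional assay on SN12C cells (Homo sapiens) for inhibition (on this read-out higher numbers stand for weaker inhibition of growth and lower numbers for stronger inhibition of growth), compound 1 gives 1780 nM. Compound 2, `C=C1CCC[C@H]2[C@](C)(CCC(C)=O)[C@@H](C)CC[C@]12C`, lacks the peroxide ring and the carboxylic acid side chain; in this assay compound 2 gives only a limit, > 15000 nM, and no number, (the limit of > 15000 nM in this assay, at which 1 of the 2 values shown sits). For the measured compounds named here, no pair of measured compounds differs in a single place, so no measured step is available to calibrate the series.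

Compound 3, `C=C1CCC[C@H]2[C@](C)(CC[C@]3(C)CC[C@@H]([C@@H](C)C(=O)O)OO3)[C@@H](C)CC[C@]12C`, is the next candidate. It differs from compound 1 as follows: the two compounds have the same atoms and bonds and differ only in configuration as drawn: 1 of 7 stereo elements differ; a stereocentre at a saturated ring carbon is drawn R in compound 1 and S in compound 3. The stereocentre concerned is the one that carries the carboxylic acid side chain on the peroxide ring, so the change moves that side chain to the opposite face of the ring without altering any other stereo element.

Going by the values given here, with no measured stereochemical step in the set, the step from compound 1 to compound 3 is expected to be small, a 1.4-fold higher number from compound 1 to compound 3 (0.15 log units; within the scatter), and may well lie within the scatter. Compound 3 is therefore estimated at 2500 nM in this assay, with a plausible range from 800 nM to 8000 nM.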

Compound 3, concentration for 50% growth inhibition: 780 nM
Compound 3: middle estimate off by 3.2-fold (0.51 log units), on the high side; measured number outside the range, below it.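

In this assay, the ring carbon that carries the carboxylic acid side chain on the peroxide ring now has a measured stereochemical step, a 2.3-fold lower number from compound 1 to compound 3 (0.36 log units; beyond the scatter), so configuration at this position registers on the read-out. The S configuration drawn in compound 3 goes with the lower number, which stands for stronger inhibition of growth, and this step can be tied to that single stereocentre, with the other stereo elements unchanged: the fact that compounds 1 and 3 differ only in the configuration as drawn. The step is modest, and compound 1 and compound 3 both give numbers rather than a limit, so inhibition of growth is measurable in this series with the side chain on either face of the ring.

On these data alone, what the carboxylic acid itself contributes on either epimer remains open, as does whether a methyl ester or a primary amide in its place would keep the same preference for the S configuration. The peroxide ring also remains unresolved, since no pair among the compounds shown differs in that ring alone.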